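Cyclohexyl to Phenyl on an Inactive Pair

The source may hold more compounds than are shown below. What is called first, only, known or untested is meant among the compounds shown, and "the series" means these compounds.

Compound 1 `Cc1ccccc1Nc1nc(NC2CC2)ncc1Cl` and compound 2 `Cc1ccccc1Nc1nc(NC2CCCCC2)ncc1Cl` share one core and differ only in the group on one nitrogen. In a functional assay on Jurkat cells (Homo sapiens) for inhibition, read by CCK-8 assay, with a stated time of 48 h (on this read-out higher numbers stand for weaker inhibition of growth and lower numbers for stronger inhibition of growth), compound 1 gives > 100000 nM, which is a limit of the assay and not a number. Compound 2 gives > 100000 nM, which is likewise a limit. Compound 2 therefore stands at the limit of > 100000 nM in this assay, at which 2 of the 2 values shown sit.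

The next change leads to compound 3 `Cc1ccccc1Nc1nc(Nc2ccccc2)ncc1Cl`, with phenyl in place of cyclohexyl on a nitrogen on an aromatic ring. Among the compounds with values here, the only measured step, a step that the two limits leave unreadable from compound 1 to compound 2, has no size to carry forward, so at most a small gain in this assay is expected, and a further limit is quite possible. The expected change is an at least 1.4-fold lower number from compound 2 to compound 3 (0.15 log units; that floor lies within the scatter). For compound 3 the estimated value is 70000 nM, with an expected range of 20000 nM to 100000 nM.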

Compound 3, concentration for 50% growth inhibition: > 100000 nM
Compound 3: only a limit was reported; the forecaster's own chance of this, stated with the estimate: 65%; at least 1.4-fold (0.15 log units) between middle value and limit.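

No step can be read among compound 1, compound 2 and compound 3, since each result is a limit of the assay and not a number: the limit of > 100000 nM in this assay, at which 3 of the 3 values shown sit. These compounds leave open whether any group on that nitrogen would give a value that can be read as a number.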